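Moving the fluorine on the hydrazone aryl ring

This account rests on a few compounds, and the source may have more. Where it says the series, first, only, none or still open, it means among the compounds named here.

Measured compounds:
compound 1, `O=C(N/N=C/c1ccccc1)c1cccnc1Nc1cccc(C(F)(F)F)c1`, 53.9%
compound 2, `O=C(N/N=C/c1cccc(F)c1)c1cccnc1Nc1cccc(C(F)(F)F)c1`, 51.5%

Both numbers come from a functional assay on the whole organism (strain Wistar) for inhibition, with Rattus norvegicus as the target, read by paw edema, with a stated time of 1 h, at a dose of 10 mg/kg by the intraperitoneal route; a higher number here means more inhibition at the dose given (going by the name of the read-out), a lower number less inhibition. Compound 2 stands lowest of the two, with compound 1 nearest; the step of a number 2.4 percentage points lower from compound 1 to compound 2 (within the scatter) lies within the scatter, so no order between them can be claimed. Compound 3, `O=C(N/N=C/c1ccc(F)cc1)c1cccnc1Nc1cccc(C(F)(F)F)c1`, differs from compound 2 by 4-fluorophenyl in place of 3-fluorophenyl on a carbon with a double bond to nitrogen. Going by the values given here, no measured step moves a fluorine from one ring position to another, and the only step known, a fluorine in place of hydrogen, was small, so compound 3 is expected to give a step of a number 0.5 percentage points higher from compound 2 to compound 3 (within the scatter), within the scatter. Compound 3 is therefore estimated at 52%, between 40% and 64%.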

Compound 3, a percentage reported as inhibition, in the whole organism at one dose (the size of the read-out at that dose, not a potency): 43.2%
Compound 3: middle estimate off by 8.8 percentage points, on the high side, within the range that was stated.
By their numbers in this assay, from the lowest: compounds 3, 2 and 1 (each within the scatter of the next, the first and the last beyond it).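

In this assay the change to 4-fluorophenyl in place of 3-fluorophenyl gives a number 8.3 percentage points lower from compound 2 to compound 3 (within the scatter) and so the two fluorine placements cannot be ordered. Going by these compounds alone, the comparison with the unfluorinated phenyl group is what shows something new, with a number 10.7 percentage points lower from compound 1 to compound 3 (beyond the scatter) as the first fluorine step at this place to pass the scatter. Nothing shown offers an explanation for this difference.

As far as these compounds go, whether a chlorine, a methoxy group or an amine on this aryl ring would give a number like those of the fluorinated compounds stays open. Also open is whether the small gaps among these compounds would hold at other doses or times.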